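A few compounds are considered here, and "the series" means these few. Any claim that something is new, unique, unknown or untested is made for them only; others in the source may bear on it.

Measured compounds in a physicochemical assay for metabolic stability, read by HPLC, in phosphate buffer, with a stated time of 12 h, at pH 6.8 (on this read-out higher numbers stand for a longer-lived compound and lower numbers for a shorter-lived compound), so far:
Compound 1 `O=C(O)[C@@H](CO)NC(=O)[C@H]1C[C@H](O)CN1` at > 12 h
Compound 2 `O=C(O)[C@H](CO)NC(=O)[C@H]1C[C@@H](O)CN1` at > 12 h
Compound 3 `O=C(O)[C@H](CO)NC(=O)[C@@H]1C[C@H](O)CN1` at > 12 h

Compound 3 stands at > 12 h as a limit of the assay and not as a number. The series as a whole rests on the limit of > 12 h in this assay, at which 3 of the 3 values shown sit, and no number lies behind any of its entries.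

Compound 4 `O=C(N[C@H](CO)C(=O)O)[C@@H]1C[C@@H](O)CN1` is the next case. Its change from compound 3 is the two compounds have the same atoms and bonds and differ only in configuration as drawn: 2 of 3 stereo elements differ; a stereocentre at a saturated chain carbon is drawn S in compound 3 and R in compound 4; a stereocentre at a saturated ring carbon is drawn S in compound 3 and R in compound 4 in which a stereocentre at a saturated chain carbon is drawn S in compound 3 and R in compound 4 and a stereocentre at a saturated ring carbon is drawn S in compound 3 and R in compound 4.

Among the measured compounds shown here, three measured steps bear on this change, each one a change of configuration alone. They are a step that the two limits leave unreadable from compound 1 to compound 2 then a step that the two limits leave unreadable from compound 1 to compound 3 then a step that the two limits leave unreadable from compound 2 to compound 3 and none of them has a readable size.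

In this assay the expected result is a step that the limit leaves unreadable from compound 3 to compound 4 and no step beyond the scatter is expected in either direction. This expectation rests on the limit of > 12 h in this assay, at which 3 of the 3 values shown sit, and on nothing finer. Compound 4 is estimated at 15 h with an expected range from 12 h to 30 h and a report of only a limit is the likely outcome.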

Compound 4, half-life: > 12 h
Compound 4: a limit, no number; the forecaster's own chance of this, stated with the estimate: 90%; the middle value lies beyond the limit too.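

In this assay compound 4 gives > 12 h, a limit of the assay and not a number. No step can be read from compound 1, compound 2 or compound 3 to compound 4. The compounds shown leave open whether these configurations differ in half-life at all, with every entry resting on one limit: the limit of > 12 h in this assay, at which 4 of the 4 values shown sit.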